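Ethoxy for cyano on a biaryl amine core

The source may report more compounds than this note shows. Statements on the series, on what has been measured and on what is new or still open speak of the compounds shown alone.

The measured compounds:
compound 1 `Oc1ccccc1CNc1ccc(-c2ccc(F)cc2)cc1` with 3860 nM
compound 2 `Oc1ccccc1CNc1ccc(-c2ccc(C(F)(F)F)cc2)cc1` with "not active" (no number reported)
compound 3 `N#Cc1ccc(-c2ccc(NCc3ccccc3O)cc2)cc1` with "not active" (no number reported)

In a functional assay on Jurkat cells (Homo sapiens) for activation, with a stated time of 24 h (on this read-out higher numbers stand for an effect only at larger amounts of compound and lower numbers for an effect already at smaller amounts), compound 1 is the only one of the three that gives a number, at 3860 nM. Compound 2 is reported in this assay as "not active" (no number reported), without a number. Compound 3 likewise stands in this assay as "not active" (no number reported), so no numerical position can be given for it; it shares this outcome with compound 2, and only compound 1 gives a measurable value.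

Compound 4 `CCOc1ccc(-c2ccc(NCc3ccccc3O)cc2)cc1` has not been measured in this assay. Its difference from compound 3 is ethoxy in place of cyano on an aromatic carbon. Going by the values given here, no step between measured compounds covers a change of this kind, and compound 3 itself has no number, so the direction of the step cannot be fixed from the data; the one number available, that of compound 1, suggests that any activity is weak. The expected result for compound 4 in this assay is estimated at 5000 nM, within a range from 1500 nM to 20000 nM, with a substantial chance that again no number is reported.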

Compound 4, half-maximal effective concentration: 520 nM
Compound 4: the middle estimate sits 9.6-fold (0.98 log units) above what was measured, outside the stated range (below it).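

In this assay, the position para to a large group proves able to carry a group that gives a clear value: with ethoxy there a number appears, whereas with cyano compound 3 stands as "not active" (no number reported). Against fluoro, the change gives a 7.4-fold lower number from compound 1 to compound 4 (0.87 log units; beyond the scatter), so this position shifts the read-out by degree as well as deciding whether a number appears at all, while the steps to compound 4 from compound 2 and compound 3 cannot be read. Nothing among the data shown accounts for this result.

The compounds shown leave open whether ethoxy is special at this position or whether methoxy, or a longer chain such as propoxy, would read the same way. They also leave open how an amine or a carboxylic acid would fare there.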